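The source may report more compounds than this note shows. Statements on the series, on what has been measured and on what is new or still open speak of the compounds shown alone.

Measured compounds: compound 1 `COc1ccc(-c2cc(=O)c3c(OC)cc(OC)cc3[nH]2)cc1`, > 31100 nM; compound 2 `COc1ccc(-c2cc(=O)c3c(OC)cc(OC)cc3n2S(=O)(=O)c2ccc(C)c([N+](=O)[O-])c2)cc1`, > 51700 nM; compound 3 `COc1ccc(-c2cc(=O)c3c(OC)cc(OC)cc3n2S(=O)(=O)Cc2ccccc2)cc1`, > 34400 nM.

In a functional assay on KOPN-8 cells (Homo sapiens) for antiproliferative activity, with a stated time of 72 h (on this read-out higher numbers stand for an effect only at larger amounts of compound and lower numbers for an effect already at smaller amounts), each of these values is a limit of the assay, not a number. Compound 1 sits at the limit of > 31100 nM in this assay, at which 1 of the 3 values shown sits. Compound 3 sits at the limit of > 34400 nM in this assay, at which 1 of the 3 values shown sits. Compound 2 sits at the limit of > 51700 nM in this assay, at which 1 of the 3 values shown sits. Compound 3 therefore stands at one limit beside two others, with no readable place among them. Compound 4 `COc1ccc(-c2cc(=O)c3c(OC)cc(OC)cc3n2S(=O)(=O)c2ccc(Br)s2)cc1` differs from compound 3 in one place: 5-bromothiophen-2-yl in place of benzyl on a sulfonyl sulfur. The measured steps bearing on this sulfonyl position are a step that the two limits leave unreadable from compound 1 to compound 3 and a step that the two limits leave unreadable from compound 2 to compound 3, neither of readable size. No step beyond the scatter is therefore expected in this assay, and the estimate means a step that the limit leaves unreadable from compound 3 to compound 4. Compound 4 is expected at 40000 nM, within 15000 nM to 100000 nM, most likely again only a limit.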

Compound 4, half-maximal effective concentration: > 48200 nM
Compound 4: no number, only a limit; the forecaster's own chance of this, stated with the estimate: 85%; middle value at least 1.2-fold (0.08 log units) away from the limit.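

Compound 4 also gives only a limit of the assay, and its steps from compound 1, compound 2 and compound 3 cannot be read. The compounds shown leave open at what concentration any of these four would act in this assay.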